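The source may report more compounds than this note shows. Statements on the series, on what has been measured and on what is new or still open speak of the compounds shown alone.

Compound 1 `CCOC(=O)c1sc2cc(Oc3ccnc(C(=O)NC)c3)ccc2c1C`: > 100000 nM
Compound 2 `CNC(=O)c1cc(Oc2ccc3c(C)c(C(=O)O)sc3c2)ccn1`: > 100000 nM

In an ADME assay on HeLa cells (Homo sapiens) for cytotoxicity, read by MTT assay, with a stated time of 2 days (a lower number here means that less compound is tolerated, a higher number that more compound is tolerated), compound 2 gives > 100000 nM, which is a limit of the assay and not a number. Compound 1 gives > 100000 nM, which is also a limit. Within the data shown here, the whole series so far stands at one point: the limit of > 100000 nM in this assay, at which 2 of the 2 values shown sit. The position of compound 2 is therefore known only as a limit.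

The next compound is compound 3 `CNC(=O)c1cc(Oc2ccc3c(C)c(C(=O)OCc4ccccc4)sc3c2)ccn1`. The change from compound 2 is benzyl in place of hydrogen on an oxygen next to a carbonyl group, with benzyl in place of hydrogen on an oxygen next to a carbonyl group, which also reads as carboxy to benzyloxycarbonyl.

One measured step falls on this same oxygen: a step that the two limits leave unreadable from compound 1 to compound 2. It offers no size to carry over, and the data hold no measured number for any compound in the series. No step beyond the scatter is expected in this assay, in either direction, and another reading at the limit is the likeliest outcome. The expected change is a number no higher from compound 2 to compound 3 (the limit leaves the size open). For compound 3 the estimated value is 100000 nM, with an expected range from 30000 nM to 200000 nM.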

Compound 3, half-maximal cytotoxic concentration: 18100 nM
The estimate for compound 3 lay 5.5-fold (0.74 log units) above the measured number; the whole stated range lies above it.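

In this assay, the group on this oxygen next to a carbonyl group can move the reading: benzyl in place of hydrogen gives an at least 5.5-fold lower number from compound 2 to compound 3 (0.74 log units; beyond the scatter), and phenyl in place of methyl on the saturated chain carbon gives an at least 5.5-fold lower number from compound 1 to compound 3 (0.74 log units; beyond the scatter). The step between the ethyl and hydrogen forms cannot be read, so this place showed no effect on the read-out until compound 3, which gives 18100 nM, a measured number and not a limit. Tolerance in this series is therefore not fixed by the shared core alone, and compound 3 is the one compound shown with a number, while the other two values are limits of the assay: the limit of > 100000 nM in this assay, at which 2 of the 3 values shown sit.

On these data alone, both readable steps have only a lower bound on their size, so how far the benzyl change truly reaches in this assay remains unknown. As far as these compounds go, it also remains open whether the six-membered aromatic ring itself matters or whether a longer chain such as butyl, or a phenethyl group on the same oxygen, would give a similar number.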